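The source may hold more compounds than are shown below. What is called first, only, known or untested is meant among the compounds shown, and "the series" means these compounds.

Measured so far:
- compound 1, `Nc1cc(-c2nc(C(c3ccc(F)cc3)c3ccc(F)cc3)sc2CC(=O)O)cc(F)n1`: 30%
- compound 2, `O=C(O)Cc1sc(NC(=O)c2ccccc2)nc1-c1ccc(Cl)cc1`: 50%
- compound 3, `O=C(O)Cc1sc(C(c2ccccc2)c2ccccc2)nc1-c1cccc(F)c1`: 80%

Three compounds have been run in an in vitro functional assay on HEK285-7 cells for antagonist activity at prostaglandin D2 receptor 2 (Homo sapiens), read by BRET and beta-arrestin recruitment; on this read-out higher numbers stand for larger maximal responses and lower numbers for smaller maximal responses. Compound 1 gives 30%, the smallest maximal response of the three. Compound 2 reaches 50%, a gap from compound 1 that lies beyond the usual scatter, and compound 3 reaches 80%, the largest of the set and also well beyond the scatter from compound 1. No two of these compounds differ in just one place, so no single structural step can be read off from the measured numbers.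

Compound 4, `Cc1cc(-c2nc(C(c3ccc(F)cc3)c3ccc(F)cc3)sc2CC(=O)O)cnc1N`, has not yet been measured. It differs from compound 1 in one place only: 6-amino-5-methylpyridin-3-yl in place of 2-amino-6-fluoropyridin-4-yl on an aromatic carbon. The other parts of the molecule are kept as they are in compound 1.

Among the measured compounds shown here, since the measured compounds give no step of this kind, the direction has to be guessed. The expected step from compound 1 to compound 4 in this assay is a number 15 percentage points higher from compound 1 to compound 4 (beyond the scatter), a modest rise that may only just clear the scatter. Compound 4 is therefore expected to give about 45%, with a likely range from 25% to 70%.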

Compound 4, largest response reached (reported as efficacy), in percent of the reference or control that the assay uses: 80%
Compound 4: the middle estimate sits 35 percentage points below what was measured, and the stated range ends below it.
By their numbers in this assay, from the lowest: compound 1; then compound 2; then compounds 3 and 4 (each within the scatter of the next).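

In this assay, putting 6-amino-5-methylpyridin-3-yl in place of 2-amino-6-fluoropyridin-4-yl gives a number 50 percentage points higher from compound 1 to compound 4 (beyond the scatter), so the maximal response depends strongly on which of these two amino-bearing pyridine groups sits on this aromatic carbon. The two groups match in heavy-atom, hydrogen-bond donor and hydrogen-bond acceptor counts and neither carries a net charge, so these counts alone do not separate them. Nothing shown here explains why the step is this large.

The change swaps fluorine for methyl and also alters how the pyridine is attached and arranged, so the compounds shown cannot say which of these differences matters. Also open, on these data alone, is how the response would change on a pyridine carrying a methoxy group or a chlorine atom in place of the amine.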